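The source may hold more compounds than are shown below. What is called first, only, known or untested is meant among the compounds shown, and "the series" means these compounds.

Measured in a physicochemical assay for solubility, read by HPLC, using the shake flask method, with a stated time of 2 h, at pH 2; a higher number here means a more soluble compound, a lower number a less soluble compound:
- compound 1 `Nc1ncc(-c2ccc(C(=O)N3CC(O)C3)cc2)nc1-c1ccc(C(F)(F)F)cc1`: 110000 nM
- compound 2 `NC(=O)c1ccc(-c2cnc(N)c(-c3ccc(C(F)(F)F)cc3)n2)cc1`: 80000 nM
- compound 3 `Nc1ncc(-c2ccc(C(=O)O)cc2)nc1-c1ccc(C(F)(F)F)cc1`: < 5000 nM (a limit, not a number)

Compound 3 stands at a limit of the assay, as the limit of < 5000 nM in this assay, at which 1 of the 3 values shown sits, records. Compound 4 `Nc1ncc(-c2ccc(C(=O)N3CCC(N)C3)cc2)nc1-c1ccc(C(F)(F)F)cc1` carries 3-aminopyrrolidin-1-yl in place of hydroxy on a carbonyl carbon. For the measured compounds named here, two measured steps bear on this, and both are large: an at least 22-fold lower number from compound 1 to compound 3 (1.34 log units; beyond the scatter) and an at least 16-fold lower number from compound 2 to compound 3 (1.20 log units; beyond the scatter). Each puts hydroxy on that carbonyl carbon, so the change to compound 4 runs the opposite way. The step of a 1.4-fold lower number from compound 1 to compound 2 (0.14 log units; within the scatter) suggests that the group replacing hydroxy need not matter greatly. A large rise in this assay is therefore expected, an at least 24-fold higher number from compound 3 to compound 4 (1.38 log units; beyond the scatter). The estimate for compound 4 is 120000 nM, with an expected range of 50000 nM to 400000 nM.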

Compound 4, solubility: 165000 nM
For compound 4 the middle estimate is 1.4-fold (0.14 log units) below the measured one; the range from low to high includes it.
By their numbers in this assay, from the lowest: compounds 2, 1 and 4 (each within the scatter of the next, the first and the last beyond it). At a limit, below all of these: compound 3.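

In this assay a third group in place of hydroxy on the carbonyl carbon, 3-aminopyrrolidin-1-yl, also gives a large step from the carboxy compound (an at least 33-fold higher number from compound 3 to compound 4 (1.51 log units; beyond the scatter)). Among the groups replacing hydroxy, a gap beyond the scatter now appears, a modest one against amino (a 2.1-fold higher number from compound 2 to compound 4 (0.31 log units; beyond the scatter)), while the step against 3-hydroxyazetidin-1-yl stays within it (a 1.5-fold higher number from compound 1 to compound 4 (0.18 log units; within the scatter)). Compound 3 stands at a limit, so the first step gives only a bound: the limit of < 5000 nM in this assay, at which 1 of the 4 values shown sits.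

The compounds shown do not separate the amine of compound 4 from its five-membered ring. An unsubstituted pyrrolidine or an open-chain amine on the same carbonyl carbon would bear on that.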